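A few compounds are considered here, and "the series" means these few. Any claim that something is new, unique, unknown or untested is made for them only; others in the source may bear on it.

Measured so far:
- compound 1, `CCc1ccccc1-n1nncc1CN1C(=O)C2(C(C#N)=C(N)Oc3c(N)cc4nc5ccccc5nc4c32)c2ccccc21`: 10300 nM
- compound 2, `N#CC1=C(N)Oc2c(N)cc3nc4ccccc4nc3c2C12C(=O)N(Cc1cnnn1-c1cccc(Br)c1)c1ccccc12`: 26100 nM

Both compounds were tested in a functional assay on HCT-116 cells (Homo sapiens) for antiproliferative activity, read by MTT assay, with a stated time of 48 h; on this read-out lower numbers stand for stronger inhibition and higher numbers for weaker inhibition. Within the data shown here, of the two numbers, compound 2 gives the higher one, the nearest being compound 1, and the only step measured between them, a 2.5-fold higher number from compound 1 to compound 2 (0.40 log units; beyond the scatter), came from exchanging the aryl group on the triazole nitrogen.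

Compound 3, `N#CC1=C(N)Oc2c(N)cc3nc4ccccc4nc3c2C12C(=O)N(Cc1cnnn1-c1cccc(C(F)(F)F)c1)c1ccccc12`, has not yet been measured. It differs from compound 2 in one place: trifluoromethyl in place of bromo on an aromatic carbon. Among the measured compounds shown here, no measured step exchanges one substituent for another on the same aryl ring, so nothing among the two values bears directly on this change; the step from compound 1 to compound 2 concerns a different pair of aryl groups and only shows that this part of the molecule can move the number modestly.

On that basis compound 3 is expected to stay close to compound 2, with an estimated step of a 1.0-fold lower number from compound 2 to compound 3 (0.02 log units; within the scatter), no larger than the scatter in either direction. The estimate for compound 3 in this assay is 25000 nM, with a range from 10000 nM to 60000 nM.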

Compound 3, half-maximal inhibitory concentration: 18900 nM
Estimate against measurement, compound 3: 1.3-fold (0.12 log units) above; measured number inside the range.
By their numbers in this assay, from the lowest: compounds 1, 3 and 2 (each within the scatter of the next, the first and the last beyond it).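

In this assay, exchanging bromo for trifluoromethyl on the aryl ring, one heavy atom for four at the same place, produces a 1.4-fold lower number from compound 2 to compound 3 (0.14 log units; within the scatter), so the two groups cannot be told apart at this position. The other comparison, a 1.8-fold higher number from compound 1 to compound 3 (0.26 log units; within the scatter), is also within the scatter, which places compound 3 within the scatter of both compound 1 and compound 2, even though those two lie beyond it from each other. No measurement offered here explains why these aryl groups read as they do.

The compounds shown leave open whether an amine or a carboxylic acid on this aromatic carbon would move the number beyond the scatter. They also leave open whether a longer chain there would do so.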